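Benzyl in place of a substituted phenyl on the shared core

The source may report more compounds than this note shows. Statements on the series, on what has been measured and on what is new or still open speak of the compounds shown alone.

- compound 1 `CCCCCCCCc1ccc(OCC(=O)Cn2nnc(-c3ccccc3)n2)cc1`: 33%
- compound 2 `CCCCCCCCc1ccc(OCC(=O)Cn2nnc(-c3ccc(Cl)cc3)n2)cc1`: 74%
- compound 3 `CCCCCCCCc1ccc(OCC(=O)Cn2nnc(-c3ccc(S(=O)(=O)N(C)C)cc3)n2)cc1`: 65%

In an ADME assay on S9 fraction from liver (Rattus norvegicus) for metabolic stability, read by LC-MS, using NADPH, with a stated time of 30 min (a higher number here means that more of the compound is left, a lower number that less of the compound is left), compound 3 gives 65% and so lies within the scatter of compound 2 and well clear of compound 1. The unmeasured compound 4 `CCCCCCCCc1ccc(OCC(=O)Cn2nnc(Cc3ccccc3)n2)cc1` carries benzyl in place of 4-(dimethylsulfamoyl)phenyl on an aromatic carbon. For the measured compounds named here, two measured steps bear on this change. Chloro in place of hydrogen on an aromatic carbon gave a number 41 percentage points higher from compound 1 to compound 2 (beyond the scatter), and dimethylsulfamoyl in the same place gave a number 32 percentage points higher from compound 1 to compound 3 (beyond the scatter). Both are large. Compound 4 loses the dimethylsulfamoyl group and, like compound 1, has an aromatic ring with no added group. Going by the values given here, no compound with benzyl has been measured, however, so this comparison is only a rough guide. A large downward step is therefore expected, estimated as a number 27 percentage points lower from compound 3 to compound 4 (beyond the scatter). For compound 4 the expected value is 38%, with an estimated range from 15% to 62%.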

Compound 4, percent of the compound remaining: < 5%
Compound 4 ended at the assay's limit; the forecaster's own chance of this, stated with the estimate: 2%; middle value at least 33 percentage points from the limit.
By their numbers in this assay, from the lowest: compound 1; then compounds 3 and 2 (each within the scatter of the next). At a limit, below all of these: compound 4.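

In this assay compound 4 gives < 5%, which is a limit of the assay and not a number: the limit of < 5% in this assay, at which 1 of the 4 values shown sits. The earlier compounds shown here varied only the group added to a phenyl ring, whereas this change replaces the phenyl itself with benzyl, and the result is a number at least 60 percentage points lower from compound 3 to compound 4 (beyond the scatter) and a number at least 69 percentage points lower from compound 2 to compound 4 (beyond the scatter). The comparison with the phenyl that has no added group gives a number at least 28 percentage points lower from compound 1 to compound 4 (beyond the scatter), so the loss of the dimethylsulfamoyl group alone does not account for the result of compound 4.

From the compounds shown here alone, it remains open whether chloro or dimethylsulfamoyl on the benzyl ring would raise the number as they do on phenyl. Also open, going by these compounds, is how a longer chain such as 2-phenylethyl, or an amine or a carboxylic acid at this place, would fare in this assay.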